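Hydrogen for Chloro on the Sulfonyl Ring, Near the Assay Edge

A few compounds are considered here, and "the series" means these few. Any claim that something is new, unique, unknown or untested is made for them only; others in the source may bear on it.

Compound 1 `CCOc1ccc(F)cc1C(C)NC(=O)NS(=O)(=O)c1ccccc1`: > 300000 nM
Compound 2 `CCOc1ccc(F)cc1C(C)NC(=O)NS(=O)(=O)c1ccc(Cl)cc1`: > 300000 nM
Compound 3 `CCOc1ccc(Cl)cc1C(C)NC(=O)NS(=O)(=O)c1ccc(Cl)cc1`: 281000 nM
Compound 4 `CCOc1ccc(Cl)cc1C(C)NC(=O)NS(=O)(=O)c1ccccc1`: not yet measured

In a functional assay on thoracic aorta (Rattus norvegicus, strain Wistar), with a stated time of 15 min (a lower number here means that less compound is needed, a higher number that more compound is needed for the effect), compound 1 gives only a limit, > 300000 nM. Compound 2 likewise gives only a limit in this assay, > 300000 nM. Among the measured compounds shown here, compound 3 gives 281000 nM, the sole number among the three. Compound 1 and compound 2 both sit at the limit of > 300000 nM in this assay, at which 2 of the 3 values shown sit. The step of an at least 1.0-fold lower number from compound 2 to compound 3 (0.02 log units; that floor lies within the scatter) lies within the scatter. Compound 4 differs from compound 3 by hydrogen in place of chloro on an aromatic carbon. The matching change between compound 1 and compound 2 is the step that bears on it, but a step that the two limits leave unreadable from compound 1 to compound 2 cannot be sized. Compound 4 is therefore expected to show no step beyond the scatter, a 1.2-fold higher number from compound 3 to compound 4 (0.10 log units; within the scatter). Compound 4 is estimated at 350000 nM, between 150000 nM and 900000 nM, with a limit rather than a number quite likely.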

Compound 4, half-maximal effective concentration: > 300000 nM
Compound 4: a limit, no number; the forecaster's own chance of this, stated with the estimate: 60%; the middle value does not contradict the limit.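

In this assay compound 4 gives > 300000 nM, which is a limit and not a number. Hydrogen in place of chloro on this aromatic carbon gives an at least 1.0-fold higher number from compound 3 to compound 4 (0.02 log units; that floor lies within the scatter), so for the first time this change has a readable floor, though that floor shows nothing beyond the scatter. The steps between two limits cannot be read, and most of the set now sits at one limit: the limit of > 300000 nM in this assay, at which 3 of the 4 values shown sit.

What the compounds shown leave open is whether an amine or a carboxylic acid at this position, para to a large group, would give a number clear of that limit.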